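Working notes on compound 3 before its tolerability readout

The compounds below may be only part of what the source reports. "The series", "measured", "known", "first", "only" and "open" are said of these compounds alone.

Measured so far:
Compound 1 `CCCCc1ccc(-c2ccc3ncc(-c4noc(CC)n4)cc3c2)cc1` gives in a functional assay on RD cells (Homo sapiens) for inhibition, read by luminescence and ATP content, with a stated time of 72 h (a lower number here means that less compound is tolerated, a higher number that more compound is tolerated), a reading of > 7400 nM, which is a limit of the assay and not a number.
Compound 2 `CCc1nc(-c2cnc3ccc(-c4ccc(N)c(Cl)c4)cc3c2)no1` gives in this assay a reading of > 7400 nM, likewise a limit of the assay.

Where compound 2 stands: its reading sits at the limit of > 7400 nM in this assay, at which 2 of the 2 values shown sit. Among the measured compounds shown here, nothing else is known for it, and no step between two measured compounds can be drawn, since neither value is a number.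

Compound 3 `CCc1nc(-c2cnc3ccc(-c4ccc(Cl)cc4)cc3c2)no1` differs from compound 2 in one place: 4-chlorophenyl in place of 4-amino-3-chlorophenyl on an aromatic carbon of the shared core.

What to expect: with both measured readings resting at the same limit of this assay, no direction can be set for the change from compound 2 to compound 3. The step from compound 2 to compound 3 is therefore expected to be a step that the limit leaves unreadable from compound 2 to compound 3, that is, none beyond the usual scatter. For compound 3 the estimate in this assay is 8000 nM, with an expected range from 3700 nM to 20000 nM, and it is most likely that the assay again reports only a limit rather than a number.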

Compound 3, half-maximal cytotoxic concentration: > 22200 nM
Compound 3: a limit, no number; the forecaster's own chance of this, stated with the estimate: 80%; middle value at least 2.7-fold (0.44 log units) away from the limit.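

In this assay compound 3 gives > 22200 nM, which is a limit and not a number. Among the compounds shown here, the readings of compound 1 and compound 2 are limits as well, so no step from either to compound 3 can be read. The compounds shown leave open the concentration at which any of the three reaches half-maximal cytotoxicity.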